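The source may hold more compounds than are shown below. What is called first, only, known or untested is meant among the compounds shown, and "the series" means these compounds.

Measured in a functional assay on MCF7 cells (Homo sapiens) for antiproliferative activity, read by MTT assay, with a stated time of 72 h; a lower number here means a stronger inhibitor, a higher number a weaker inhibitor:
- Compound 1 `CC(C)(C)c1ccc(/C=C/C(=O)c2ccc(OCC(=O)N[C@H]3CCOC3=O)cc2)cc1` gives 16400 nM
- Compound 2 `CC(C)c1ccc(/C=C/C(=O)c2ccc(OCC(=O)N[C@H]3CCOC3=O)cc2)cc1` gives 23400 nM
- Compound 3 `O=C(COc1ccc(C(=O)/C=C/c2ccccc2)cc1)N[C@H]1CCOC1=O` gives > 64000 nM, a limit and not a number

Compound 3 stands at the limit of > 64000 nM in this assay, at which 1 of the 3 values shown sits; this is a limit, and it places compound 3 at the weak end of these three. Compound 4 `O=C(COc1ccc(C(=O)/C=C/c2ccc(Br)cc2)cc1)N[C@H]1CCOC1=O` differs from it by a single change: bromo in place of hydrogen on an aromatic carbon. Going by the values given here, two measured steps bear on this. Hydrogen in place of tert-butyl gave an at least 3.9-fold higher number from compound 1 to compound 3 (0.59 log units; beyond the scatter) and hydrogen in place of isopropyl gave an at least 2.7-fold higher number from compound 2 to compound 3 (0.43 log units; beyond the scatter), so adding bromo, the opposite kind of change, is expected to lower the number modestly in this assay, though bromo is neither of those groups. The expected change is an at least 2.2-fold lower number from compound 3 to compound 4 (0.35 log units; beyond the scatter). For compound 4 the estimated value is 28000 nM, with an expected range from 12000 nM to 64000 nM.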

Compound 4, half-maximal inhibitory concentration: > 64000 nM
Compound 4 ended at the assay's limit; the forecaster's own chance of this, stated with the estimate: 25%; middle value at least 2.2-fold (0.35 log units) away from the limit.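

Replacing tert-butyl with bromo on this aromatic carbon gave an at least 3.9-fold higher number from compound 1 to compound 4 (0.59 log units; beyond the scatter), and replacing isopropyl with bromo gave an at least 2.7-fold higher number from compound 2 to compound 4 (0.43 log units; beyond the scatter). Compound 4 therefore goes against any rule that simply having a group at this place lowers the number in this assay. Compound 4 sits at a limit, as compound 3 does, so the step between them cannot be read: the limit of > 64000 nM in this assay, at which 2 of the 4 values shown sit.

On these data alone, whether a carbon chain is what matters here stays open. A methoxy group, an amine or an n-butyl chain at this place could help separate that question from group size.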